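The source may report more compounds than this note shows. Statements on the series, on what has been measured and on what is new or still open speak of the compounds shown alone.

Measured so far in a functional assay on 143B cells (Homo sapiens) for antiproliferative activity, read by MTT assay, with a stated time of 48 h; a higher number here means a weaker inhibitor, a lower number a stronger inhibitor:
compound 1, `O=C(Nc1cccc(/C=C/C(=O)c2nc3ccccc3[nH]2)c1)c1cccc(Cl)c1` — 3370 nM
compound 2, `O=C(Nc1cccc(/C=C/C(=O)c2nc3ccccc3[nH]2)c1)c1cccc(C(F)(F)F)c1` — 9570 nM

Compound 1 holds the lowest of the two numbers; its nearest neighbour is compound 2, reached by a 2.8-fold higher number from compound 1 to compound 2 (0.45 log units; beyond the scatter). Compound 3, `Cc1cc(C)cc(C(=O)Nc2cccc(/C=C/C(=O)c3nc4ccccc4[nH]3)c2)c1`, is not yet measured. It differs from compound 1 by 3,5-dimethylphenyl in place of 3-chlorophenyl on a carbonyl carbon. Among the compounds with values here, the only measured step that bears on this change is the one from compound 1 to compound 2, which also alters a group on the same aromatic ring and moved the number modestly, beyond the scatter. That step does not involve a 3,5-dimethylphenyl group, so the direction for compound 3 cannot be read from it; it only shows that a change here can shift the number by a modest amount. Compound 3 is therefore expected to give a step of a 1.3-fold higher number from compound 1 to compound 3 (0.13 log units; within the scatter). Compound 3 is estimated at 4500 nM, with a range from 1500 nM to 13500 nM.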

Compound 3, half-maximal inhibitory concentration: 4020 nM
Beside the measured number, compound 3's estimate is 1.1-fold (0.05 log units) above it, and the stated range covers the measured number.
By their numbers in this assay, from the lowest: compounds 1 and 3 (each within the scatter of the next); then compound 2.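

In this assay, 3,5-dimethylphenyl in place of 3-chlorophenyl on the carbonyl carbon gives a 1.2-fold higher number from compound 1 to compound 3 (0.08 log units; within the scatter) and so shows that this position tolerates a ring with two methyl groups and no chlorine, with no change that can be told from the scatter. Measured against the 3-(trifluoromethyl)phenyl ring, the same 3,5-dimethylphenyl ring gives a 2.4-fold lower number from compound 2 to compound 3 (0.38 log units; beyond the scatter) and so shows that a new ring here need not raise the number as trifluoromethyl did; among these three compounds, only compound 2 stands apart. No measurement shown here explains why these rings differ or match.

The compounds shown leave open whether an amine or a carboxylic acid on this ring would keep the number in the same range. They also leave open whether a cyclohexyl group could replace the aromatic ring at this carbonyl carbon.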